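A few compounds are considered here, and "the series" means these few. Any claim that something is new, unique, unknown or untested is made for them only; others in the source may bear on it.

Of the compounds shown here, three with the same core have been measured in a functional assay on MDA-MB-436 cells (Homo sapiens) for antiproliferative activity, read by MTT assay, with a stated time of 48 h (on this read-out higher numbers stand for weaker inhibition and lower numbers for stronger inhibition), and they differ only in the aromatic group on that core. Compound 1 `C=CS(=O)(=O)N1CCN(c2ncnc3sc(-c4ccc(C(F)(F)F)cc4)cc23)CC1` gives 7080 nM. Compound 2 `C=CS(=O)(=O)N1CCN(c2ncnc3sc(-c4ccc(C#N)cc4)cc23)CC1` gives 9170 nM. Compound 3 `C=CS(=O)(=O)N1CCN(c2ncnc3sc(-c4ccc(F)nc4)cc23)CC1` gives 17500 nM. Two steps show where compound 3 stands: a 1.9-fold higher number from compound 2 to compound 3 (0.28 log units; within the scatter), and a 2.5-fold higher number from compound 1 to compound 3 (0.39 log units; beyond the scatter). It therefore cannot be told apart from compound 2, but it is less active than compound 1.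

Compound 4 `C=CS(=O)(=O)N1CCN(c2ncnc3sc(-c4cccs4)cc23)CC1` has not yet been measured. It has thiophen-2-yl in place of 6-fluoropyridin-3-yl on an aromatic carbon. Among the measured compounds shown here, the steps that bear on this change are the swaps already made at the same place: a 1.3-fold higher number from compound 1 to compound 2 (0.11 log units; within the scatter), along with the two steps above. For the measured compounds named here, all three are small, and only the one between compound 1 and compound 3 clears the scatter. Going by the values given here, none of the measured compounds carries a five-membered ring at this place, so these steps are only a loose guide. The estimate therefore leans towards the middle of the three values. The expected step is small, a 1.6-fold lower number from compound 3 to compound 4 (0.20 log units; within the scatter), towards a lower number and not clearly beyond the scatter. Compound 4 is estimated at 11000 nM, with an expected range from 5000 nM to 25000 nM.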

Compound 4, half-maximal inhibitory concentration: 39000 nM
The estimate for compound 4 lay 3.5-fold (0.55 log units) below the measured number; measured number above the stated range.
By their numbers in this assay, from the lowest: compounds 1, 2 and 3 (each within the scatter of the next, the first and the last beyond it); then compound 4.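

At this place, on an aromatic carbon of a five-membered aromatic ring with 1 sulfur, compound 4 brings in the first five-membered aromatic ring of the series, and in this assay it separates clearly from the other three: a 2.2-fold higher number from compound 3 to compound 4 (0.35 log units; beyond the scatter), a 4.3-fold higher number from compound 2 to compound 4 (0.63 log units; beyond the scatter) and a 5.5-fold higher number from compound 1 to compound 4 (0.74 log units; beyond the scatter). Each of these steps is beyond the scatter, so compound 4 is the least active of the four, and the position proves more sensitive to the choice of aromatic group than the small differences among compounds 1, 2 and 3 suggested. No measurement shown here explains this loss of activity.

Thiophen-2-yl differs from the other groups in two ways, having a smaller ring and no substituent on it, and these compounds cannot separate the two changes. A plain phenyl ring would test the missing substituent at the six-membered size, while a thiophen-2-yl ring carrying a trifluoromethyl group or a nitrile would test the five-membered ring with a substituent restored.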